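From 4-fluorophenyl to 4-chlorophenyl in the series

The source may report more compounds than this note shows. Statements on the series, on what has been measured and on what is new or still open speak of the compounds shown alone.

- compound 1 `COc1ccccc1-c1cccc(S(=O)(=O)N2CCC(N3CCC(C)CC3)CC2)c1`: > 5000 nM
- compound 2 `Cc1cccc(S(=O)(=O)N2CCC(N3CCC(C)CC3)CC2)c1`: > 5000 nM
- compound 3 `CC1CCN(C2CCN(S(=O)(=O)c3cccc(-c4ccc(F)cc4)c3)CC2)CC1`: > 5000 nM

All three entries come from an ADME assay on HCT-116 cells (Homo sapiens) for cytotoxicity, read by CellTiter-Glo, with a stated time of 72 h (a higher number here means a weaker inhibitor, a lower number a stronger inhibitor), and each is a limit of the assay, not a number. The summary for the set is the limit of > 5000 nM in this assay, at which 3 of the 3 values shown sit. Compound 3 therefore has no exact position, and its entry of > 5000 nM is only a limit.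

The next compound is compound 4 `CC1CCN(C2CCN(S(=O)(=O)c3cccc(-c4ccc(Cl)cc4)c3)CC2)CC1`, and the change is chloro in place of fluoro on an aromatic carbon, or 4-fluorophenyl to 4-chlorophenyl. The steps closest to it are a step that the two limits leave unreadable from compound 1 to compound 3 and a step that the two limits leave unreadable from compound 2 to compound 3, and neither has a size that can be read. The remaining one, a step that the two limits leave unreadable from compound 1 to compound 2, adds no size either. With only these steps as a guide, no step beyond the scatter is expected in this assay, and no direction can be assigned. The expected step is a step that the limit leaves unreadable from compound 3 to compound 4. The estimated value for compound 4 is 6000 nM, with an expected range of 3000 nM to 12000 nM.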

Compound 4, half-maximal inhibitory concentration: > 5000 nM
Compound 4: a limit, no number (the forecaster's own chance of this, stated with the estimate: 85%); the middle value lies beyond the limit too.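

Compound 4 gives > 5000 nM in this assay as a limit, and its steps from compound 1, compound 2 and compound 3 cannot be read. The compounds shown leave open how these four rank and which change on the shared core would give a measurable value. The set now stands at one limit: the limit of > 5000 nM in this assay, at which 4 of the 4 values shown sit.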